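Swapping a urea for an amide on a pyrazole scaffold

The source may hold more compounds than are shown below. What is called first, only, known or untested is meant among the compounds shown, and "the series" means these compounds.

Measured so far:
compound 1 `COc1cc(-c2nn(-c3cccc(NC(=O)Nc4cc(C(F)(F)F)cc(C(F)(F)F)c4)c3)cc2-c2ccncc2)ccc1Cl`: 400 nM
compound 2 `COc1cc(-c2nn(-c3cccc(NC(=O)Nc4ccc(Cl)c(Cl)c4)c3)cc2-c2ccncc2)ccc1Cl`: 690 nM
compound 3 `O=C(Nc1cccc(-n2cc(-c3ccncc3)c(-c3ccc(Cl)c(O)c3)n2)c1)Nc1ccc(Cl)c(Cl)c1`: "not determined" (no result reported)

In a functional assay on SF-295 cells (Homo sapiens) for inhibition, read by sulforhodamine B assay, with a stated time of 48 h (a lower number here means a stronger inhibitor, a higher number a weaker inhibitor), compound 1 gives 400 nM and compound 2 gives 690 nM. These two numbers lie within the usual scatter of each other, so neither compound can be called the stronger one; compound 2 simply has the higher of the two numbers on record. For compound 3 this assay gives only "not determined" (no result reported).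

Compound 4 `COc1cc(-c2nn(-c3cccc(NC(=O)c4ccc(Cl)c(C(F)(F)F)c4)c3)cc2-c2ccncc2)ccc1Cl` is built from compound 2 by one change: 4-chloro-3-(trifluoromethyl)phenyl in place of (3,4-dichlorophenyl)amino on a carbonyl carbon. In plain terms, the urea linking the two aromatic rings becomes an amide, and the ring at its far end carries a trifluoromethyl in place of one of the two chlorines. For the measured compounds named here, no measured pair in this set shows the effect of such a change, so the expected step rests on the structural change alone. The step of a 2.0-fold higher number from compound 2 to compound 4 (0.31 log units; beyond the scatter) is my own estimate, and what I would expect is a modest move toward a higher number, beyond the scatter but not far beyond it. Compound 4 is therefore estimated at 1400 nM, with a range from 450 nM to 4500 nM.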

Compound 4, half-maximal inhibitory concentration: 1380 nM
Compound 4: middle estimate off by 1.0-fold (0.01 log units), on the high side; measured number inside the range.
By their numbers in this assay, from the lowest: compounds 1, 2 and 4 (each within the scatter of the next, the first and the last beyond it).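

In this assay, putting 4-chloro-3-(trifluoromethyl)phenyl in place of (3,4-dichlorophenyl)amino on the carbonyl carbon gives a 2.0-fold higher number from compound 2 to compound 4 (0.30 log units; within the scatter), the first step seen at this position. The group that leaves carries one hydrogen-bond donor and the group that enters carries none, so here the urea can become an amide, and that donor can go, without a step that stands clear of the scatter. Nothing measured here explains the size of this step.

The amide and the trifluoromethyl arrive together, so the compounds shown cannot separate what each does alone. Also open, from the compounds shown here alone, is how this carbonyl carbon would take a group carrying an amine or a carboxylic acid, or a longer chain in place of the aromatic ring.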